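Amide aryl variation on the shared core: notes

The source may hold more compounds than are shown below. What is called first, only, known or untested is meant among the compounds shown, and "the series" means these compounds.

Measured so far:
- compound 1 `O=C(CN1CCN(c2nnc(Cc3ccccc3)c3ccccc23)CC1)Nc1ccc(F)c(C(F)(F)F)c1`: 760 nM
- compound 2 `O=C(CN1CCN(c2nnc(Cc3ccccc3)c3ccccc23)CC1)Nc1ccc(Br)cc1`: 12400 nM

Both compounds were tested in a functional assay on MDA-MB-231 cells (Homo sapiens) for cytotoxicity, read by MTT assay, with a stated time of 72 h; a lower number here means a stronger inhibitor, a higher number a weaker inhibitor. Compound 2 gives the highest number of the two; its nearest neighbour is compound 1, and the step of a 16-fold higher number from compound 1 to compound 2 (1.21 log units; beyond the scatter) shows that exchanging the aryl group on the amide-type nitrogen alone can move the read-out well beyond the scatter.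

Compound 3 `Cc1ccc(NC(=O)CN2CCN(c3nnc(Cc4ccccc4)c4ccccc34)CC2)c(C)c1` is not yet measured. It differs from compound 2 as follows: 2,4-dimethylphenyl in place of 4-bromophenyl on an amide-type nitrogen. Going by the values given here, no measured step covers this pair, and no other compound carries the 2,4-dimethylphenyl group, so the size and direction of the change cannot be read from the data. Among the compounds with values here, the single measured step, from compound 1 to compound 2, only indicates that this position is sensitive. With two aryl groups on the amide-type nitrogen already far apart in this assay, the expectation for compound 3 is set near compound 2, with a wide range in both directions, and the step of a 1.4-fold lower number from compound 2 to compound 3 (0.14 log units; within the scatter) is estimated with low confidence. Compound 3 is expected at 9000 nM, within 2000 nM to 40000 nM.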

Compound 3, half-maximal inhibitory concentration: 181000 nM
The estimate for compound 3 lay 20-fold (1.30 log units) below the measured number; measured number outside the range, above it.
By their numbers in this assay, from the lowest: compound 1; then compound 2; then compound 3.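

In this assay, 2,4-dimethylphenyl in place of 4-bromophenyl on the amide-type nitrogen gives a 15-fold higher number from compound 2 to compound 3 (1.16 log units; beyond the scatter), so 4-bromophenyl does not mark the upper end of the numbers at this position, and compound 3 is now the weakest of the set. Across the full span, a 240-fold higher number from compound 1 to compound 3 (2.38 log units; beyond the scatter) is reached by changing this aryl group alone on the shared core, and both aryl groups carrying halogen give lower numbers than the one carrying only carbon, a pattern that rests on just these three compounds and has no exception among them. No available measurement accounts for these differences.

The compounds shown do not separate the entry of the two methyl groups from the loss of bromine, since both happen in the same change, and an unsubstituted phenyl would be a useful reference point for all three aryl groups. As far as these compounds go, how this position responds to a pyridine ring, a carboxylic acid on the aryl ring or a plain alkyl group on the amide-type nitrogen also stays open.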